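The compounds below may be only part of what the source reports. "The series", "measured", "known", "first", "only" and "open" are said of these compounds alone.

Working notes on the series. Compound 1 `CNC1=C(SC)C(=O)c2ncccc2C1=O` returns only a limit in a functional assay on cells (Neutrophil, Homo sapiens) for inhibition, read by WST assay, with a stated time of 20 min; a higher number here means a weaker inhibitor, a lower number a stronger inhibitor: compound 1 gives > 200000 nM. Compound 2 `NC1=C(Cl)C(=O)c2ncccc2C1=O` also returns only a limit, with > 200000 nM. Compound 3 `CS(=O)(=O)C1=C(N)C(=O)c2cccnc2C1=O` likewise gives only a limit, > 200000 nM. Between them stands a step that the two limits leave unreadable from compound 2 to compound 3, unreadable because both ends sit at the limit (the limit of > 200000 nM in this assay, at which 3 of the 3 values shown sit). Compound 3 thus stands at the limit together with the other two measured compounds, and no order among the three can be drawn.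

Compound 4 `CSC1=C(N)C(=O)c2cccnc2C1=O` differs from compound 3 by methylsulfanyl in place of methylsulfonyl on a double-bonded ring carbon. Within the data shown here, no measured step bears directly on this change; the only step available, a step that the two limits leave unreadable from compound 2 to compound 3, exchanges chloro for methylsulfonyl and is itself unreadable. Among the measured compounds shown here, compound 1 carries methylsulfanyl and gives a limit, > 200000 nM, but its amino group is methylated and no step to compound 4 is available. With every value at the limit (the limit of > 200000 nM in this assay, at which 3 of the 3 values shown sit), no direction beyond the scatter can be expected in this assay. Compound 4 is estimated at 200000 nM, range 50000 nM to 400000 nM, most likely again a limit. The expected step is a number no higher from compound 3 to compound 4 (the limit leaves the size open).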

Compound 4, half-maximal inhibitory concentration: > 150000 nM
Compound 4 gave a limit, no number; the forecaster's own chance of this, stated with the estimate: 80%; the middle value does not contradict the limit.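

In this assay compound 4 gives only a limit, > 150000 nM. Its steps from compound 1, compound 2 and compound 3 cannot be read. The compounds shown leave open how these four rank and whether any change on the shared core yields a numerical value in this assay.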